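A few compounds are considered here, and "the series" means these few. Any claim that something is new, unique, unknown or untested is made for them only; others in the source may bear on it.

Series notes, antiproliferative read-out in a functional assay on A549 cells (Homo sapiens) for antiproliferative activity, read by MTT assay, with a stated time of 72 h; on this read-out higher numbers stand for weaker inhibition and lower numbers for stronger inhibition:

compound 1, `COc1cc2ncnc(N3CCc4ccccc43)c2cc1NC(=O)/C=C/CN1CCN(C)CC1`, gives 5360 nM
compound 2, `COc1cc2ncnc(N3CCc4ccccc43)c2cc1NC(=O)/C=C/CN1CCC(CO)CC1`, gives 1980 nM
compound 3, `COc1cc2ncnc(N3CCCc4ccccc43)c2cc1NC(=O)/C=C/CN1CCN(C)CC1`, gives 7830 nM

Compound 4, `COc1cc2ncnc(N3CCCc4ccccc43)c2cc1NC(=O)/C=C/CN1CCC(CO)CC1`, is not yet measured in this assay.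

Compound 4 is obtained from compound 3 by the change (4-(hydroxymethyl)piperidin-1-yl in place of 4-methylpiperazin-1-yl on a saturated chain carbon bound to a double-bonded chain carbon). The same change has been made once before, from compound 1 to compound 2, as 4-(hydroxymethyl)piperidin-1-yl in place of 4-methylpiperazin-1-yl on a saturated chain carbon bound to a double-bonded chain carbon, and there it gave a 2.7-fold lower number from compound 1 to compound 2 (0.43 log units; beyond the scatter). Both occurrences sit at the same place, so this is the same change, not merely one of the same kind. The two cores differ by 1,2,3,4-tetrahydroquinolin-1-yl in place of 2,3-dihydro-1H-indol-1-yl on an aromatic carbon; that core difference itself gave a 1.5-fold higher number from compound 1 to compound 3 (0.16 log units; within the scatter), a step within the scatter.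

Among the measured compounds shown here, with only one earlier instance of the change, the expectation for compound 4 rests on that single pair. The step from compound 3 to compound 4 in this assay is expected to be about a 2.6-fold lower number from compound 3 to compound 4 (0.42 log units; beyond the scatter), because the same change gave a 2.7-fold lower number from compound 1 to compound 2 (0.43 log units; beyond the scatter) on a core that differs only by 1,2,3,4-tetrahydroquinolin-1-yl in place of 2,3-dihydro-1H-indol-1-yl on an aromatic carbon. On that basis compound 4 is estimated at 3000 nM in this assay, with the expected range from 1500 nM to 6500 nM.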

Compound 4, half-maximal inhibitory concentration: 6970 nM
Beside the measured number, compound 4's estimate is 2.3-fold (0.37 log units) below it; the measured number lies above the stated range.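

In this assay, 4-(hydroxymethyl)piperidin-1-yl in place of 4-methylpiperazin-1-yl gives a 1.1-fold lower number from compound 3 to compound 4 (0.05 log units; within the scatter), a step within the scatter, whereas the same change on the core of compound 1 gave a step beyond it, yet the two steps cannot be told apart: the same change on two cores in this assay, a 2.7-fold lower number (0.43 log units; beyond the scatter) from compound 1 to compound 2 and a 1.1-fold lower number (0.05 log units; within the scatter) from compound 3 to compound 4, 2.4-fold (0.38 log units) apart, within the scatter of two such steps. Read from the side of the core, the difference between the two cores gives a 3.5-fold higher number from compound 2 to compound 4 (0.55 log units; beyond the scatter), and the comparison with the earlier core step comes out the same way: the same change on two cores in this assay, a 1.5-fold higher number (0.16 log units; within the scatter) from compound 1 to compound 3 and a 3.5-fold higher number (0.55 log units; beyond the scatter) from compound 2 to compound 4, 2.4-fold (0.38 log units) apart, within the scatter of two such steps. The two pairs therefore do not show that the change carries over from one core to the other with its full size, nor do they show that its size depends on the core.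

A third core carrying both 4-methylpiperazin-1-yl and 4-(hydroxymethyl)piperidin-1-yl would be needed to settle this question. Going by these compounds, it also remains open how other amines on the same chain, such as morpholin-4-yl or dimethylamino, behave on these two cores.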